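The source may report more compounds than this note shows. Statements on the series, on what has been measured and on what is new or still open speak of the compounds shown alone.

Series notes, a functional assay on SW480 cells (Homo sapiens) for antiproliferative activity, read by MTT assay, with a stated time of 48 h; on this read-out higher numbers stand for weaker inhibition and lower numbers for stronger inhibition:

- compound 1 `CCCCCCC(CCO)n1cnc2c(Cl)ncnc21`: 16700 nM
- compound 2 `CCCCCCC(CCO)n1cnc2c(OC)ncnc21`: > 50000 nM (a limit)
- compound 3 `CCCCCCC(CCO)n1cnc2c(N(C)C)ncnc21`: > 50000 nM (a limit)

Compound 3 has no number on this assay, only the limit > 50000 nM. The same limit applies to compound 2, as the limit of > 50000 nM in this assay, at which 2 of the 3 values shown sit, records.

The next compound is compound 4 `CCCCCCCCCCCC(CCO)n1cnc2c(N(C)C)ncnc21`. The change is pentyl in place of hydrogen on a saturated chain carbon, seven bonds along the chain from an aromatic nitrogen.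

The measured steps all sit on the aromatic carbon and none touches the chain. They are an at least 2.9-fold higher number from compound 1 to compound 2 (0.47 log units; beyond the scatter), an at least 2.9-fold higher number from compound 1 to compound 3 (0.47 log units; beyond the scatter) and a step that the two limits leave unreadable from compound 2 to compound 3. They therefore bear on this change only indirectly, and its size stays poorly defined. Compound 1 at 16700 nM shows that a number can be reached in this series. A modest move towards stronger inhibition is expected, with a real chance of another limit. The expected step is an at least 1.7-fold lower number from compound 3 to compound 4 (0.25 log units; that floor lies within the scatter).

For compound 4 the estimate is 28000 nM, with an expected range of 9000 nM to 70000 nM.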

Compound 4, half-maximal inhibitory concentration: 11800 nM
For compound 4 the middle estimate is 2.4-fold (0.38 log units) above the measured one; the range from low to high includes it.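

In this assay, the saturated chain carbon is the first place shown where a change turns a limit into a number, with dimethylamino kept on the aromatic carbon: an at least 4.2-fold lower number from compound 3 to compound 4 (0.62 log units; beyond the scatter). Compound 3 stands at > 50000 nM, which is a limit. The step is therefore a floor, but it shows that the chain can move this read-out beyond the scatter, which the steps on the aromatic carbon could not show.

Going by these compounds, whether the effect of pentyl in place of hydrogen carries over with chloro or methoxy on the aromatic carbon stays open, as does the true size of the step. A longer chain, or an amine or a carboxylic acid in place of the chain's hydroxyl, would show how far this part of the compounds can be changed.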